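Methoxy to Nitro: What It Does to Cytotoxicity Numbers

A few compounds are considered here, and "the series" means these few. Any claim that something is new, unique, unknown or untested is made for them only; others in the source may bear on it.

Compound 1, `COc1ccc(/C=C(\C)C(=O)/C=C/c2ccccc2)cc1`: 44000 nM
Compound 2, `C/C(=C\c1ccc([N+](=O)[O-])cc1)C(=O)/C=C/c1ccccc1`: 264000 nM
Compound 3, `COc1ccc(/C=C/C(=O)/C(C)=C/c2ccc([N+](=O)[O-])cc2)cc1`: 172000 nM

These three compounds were tested in an ADME assay on LLC-MK2 cells (Macaca mulatta) for cytotoxicity, read by MTT assay, with a stated time of 48 h; on this read-out lower numbers stand for higher toxicity in this test and higher numbers for lower toxicity in this test. The change from compound 1 to compound 2 is nitro in place of methoxy on an aromatic carbon, and it brought a 6.0-fold higher number from compound 1 to compound 2 (0.78 log units; beyond the scatter). The further change gave a 1.5-fold lower number from compound 2 to compound 3 (0.19 log units; within the scatter). How the core of compound 1 and the core of compound 3 differ is not broken down here.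

Compound 4, `C/C(=C\c1ccc([N+](=O)[O-])cc1)C(=O)/C=C/c1ccc([N+](=O)[O-])cc1`, has not yet been measured in this assay. It differs from compound 3 by nitro in place of methoxy on an aromatic carbon, which is the same change as that from compound 1 to compound 2, at a place described in the same words. Because compound 3 gives 172000 nM and the same change earlier brought a 6.0-fold higher number from compound 1 to compound 2 (0.78 log units; beyond the scatter), compound 4 is expected to show a 3.8-fold higher number from compound 3 to compound 4 (0.58 log units; beyond the scatter). This rests on one earlier example only. The estimate for compound 4 is 650000 nM, expected to fall between 220000 nM and 2000000 nM.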

Compound 4, half-maximal cytotoxic concentration: 32500 nM
Compound 4: the middle estimate sits 20-fold (1.30 log units) above what was measured; the measured number lies below the stated range.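

On the core of compound 3, nitro in place of methoxy on an aromatic carbon gave a 5.3-fold lower number from compound 3 to compound 4 (0.72 log units; beyond the scatter), and nitro in place of hydrogen on an aromatic carbon gave an 8.1-fold lower number from compound 2 to compound 4 (0.91 log units; beyond the scatter). Among the compounds shown here, the same named change therefore did not carry from one core to the other, and its two results point in opposite directions: the same change on two cores in this assay, a 6.0-fold higher number (0.78 log units; beyond the scatter) from compound 1 to compound 2 and a 5.3-fold lower number (0.72 log units; beyond the scatter) from compound 3 to compound 4, 32-fold (1.50 log units) apart, beyond the scatter of two such steps With only one pair on each core, this shows that the step seen on one core cannot be relied on for the other, but it does not show which part of the cores makes the difference.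

The compounds shown carry only methoxy, nitro or hydrogen at these aromatic carbons. As far as these compounds go, how an amine or a carboxylic acid would behave there remains open, as does whether further pairs on either core would follow the same direction.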